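Chlorobenzyl sulfanyl series: arterial inhibition in the rat

A few compounds are considered here, and "the series" means these few. Any claim that something is new, unique, unknown or untested is made for them only; others in the source may bear on it.

Compound 1 `COc1ccc(C2N=C(SCc3ccccc3Cl)NC(C)=C2C(=O)Nc2ccc(F)cc2)cc1OC` carries a 2-chlorophenyl on a saturated chain carbon bound to a sulfur. In a functional assay on the whole organism (artery, strain albino) with Rattus norvegicus as the target, with a stated time of 60 min, at a dose of 10 mg/kg by the oral route (on this read-out lower numbers stand for less inhibition and higher numbers for more inhibition at the one dose given (going by the name of the read-out)), compound 1 gives 11.8%. Compound 2 `COc1ccc(C2N=C(SCc3cccc(Cl)c3)NC(C)=C2C(=O)Nc2ccc(F)cc2)cc1OC` shares the core of compound 1 and differs by 3-chlorophenyl in place of 2-chlorophenyl on a saturated chain carbon bound to a sulfur. In this assay compound 2 gives 8.2%. The step of a number 3.6 percentage points lower from compound 1 to compound 2 (within the scatter) therefore shows no movement that can be separated from the usual scatter of repeated measurements.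

Compound 3 `CC1=C(C(=O)Nc2ccc([N+](=O)[O-])cc2)C(c2ccc(Br)cc2)N=C(SCc2ccccc2Cl)N1` also carries the 2-chlorophenyl on a saturated chain carbon bound to a sulfur, but on another core; the difference between the core of compound 3 and the core of compound 1 is not broken down here. In this assay compound 3 gives 6.7%. That value lies within the scatter of compound 2 and of compound 1, so no order among the three can be stated.

Compound 4 `CC1=C(C(=O)Nc2ccc([N+](=O)[O-])cc2)C(c2ccc(Br)cc2)N=C(SCc2cccc(Cl)c2)N1` awaits measurement. It differs from compound 3 by 3-chlorophenyl in place of 2-chlorophenyl on a saturated chain carbon bound to a sulfur, the same change that leads from compound 1 to compound 2, made here on the core of compound 3. The expectation rests on the earlier step of a number 3.6 percentage points lower from compound 1 to compound 2 (within the scatter) staying within the scatter, and on compound 3 starting from 6.7%. The step from compound 3 to compound 4 is expected to be a number 1.2 percentage points lower from compound 3 to compound 4 (within the scatter). Compound 4 is accordingly estimated at 5.5%, with a likely range from -2% to 14%.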

Compound 4, a percentage reported as inhibition, in the whole organism at one dose (the size of the read-out at that dose, not a potency): 4.1%
Beside the measured number, compound 4's estimate is 1.4 percentage points above it; the measured number falls inside the stated range.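

In this assay, 3-chlorophenyl in place of 2-chlorophenyl on a saturated chain carbon bound to a sulfur gives a number 2.6 percentage points lower from compound 3 to compound 4 (within the scatter), so on the core of compound 3 this change again shows no movement that can be separated from the usual scatter. For the compounds shown here, the two cores give the same picture for this one change: the same change on two cores in this assay, a number 3.6 percentage points lower (within the scatter) from compound 1 to compound 2 and a number 2.6 percentage points lower (within the scatter) from compound 3 to compound 4, 1 percentage points apart, within the scatter of two such steps What this shows is limited: on both cores, the 2-chlorobenzyl to 3-chlorobenzyl swap leaves the read-out indistinguishable from repeat scatter, but this is agreement between two steps that cannot be told from no step, so it does not show that a real effect carries from one core to another, nor does it fix a direction or size for the change on any further core.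

The compounds shown leave open whether anything other than a chlorine-bearing benzyl on the sulfur would move this read-out, for instance an unsubstituted benzyl, a benzyl bearing an amine or a carboxylic acid, or a longer chain in its place. As far as these compounds go, each compound is also seen at a single oral dose and a single time, so potency and the response at other doses remain open.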